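Methoxy in place of hydrogen across two related cores

The compounds below may be only part of what the source reports. "The series", "measured", "known", "first", "only" and "open" are said of these compounds alone.

Compound 1 `COc1ccc(/C=C/C(=O)/C=C/c2cc3ccccc3nc2Cl)c(OC)c1` carries two methoxy groups on its six-membered aromatic ring. In a functional assay on NCI-H460 cells (Homo sapiens) for cytotoxicity, read by MTT assay, with a stated time of 48 h (on this read-out lower numbers stand for stronger inhibition and higher numbers for weaker inhibition), compound 1 sits at a limit of the assay, > 10000 nM. Compound 2 `COc1cc(OC)c(OC)cc1/C=C/C(=O)/C=C/c1cc2ccccc2nc1Cl` adds a third; in this assay compound 2 gives 3960 nM. The step of an at least 2.5-fold lower number from compound 1 to compound 2 (0.40 log units; beyond the scatter) follows from methoxy in place of hydrogen on an aromatic carbon. Its true size is not fixed because compound 1 sits at the limit of > 10000 nM in this assay, at which 2 of the 3 values shown sit.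

Compound 3 `COc1ccc(/C=C/C(=O)/C=C/c2cc3ccccc3nc2Oc2ccccc2)cc1OC` belongs to a second core; the difference between the two cores is not broken down here. In this assay compound 3 sits at a limit of the assay, > 10000 nM.

Compound 4 `COc1cc(OC)c(OC)cc1/C=C/C(=O)/C=C/c1cc2ccccc2nc1Oc1ccccc1` has not been measured in this assay. It differs from compound 3 by methoxy in place of hydrogen on an aromatic carbon. This is the same kind of change as that from compound 1 to compound 2, not the same: in the measured pair the entering methoxy is ortho to a methoxy group and meta to a large group, whereas in compound 4 it is ortho to a large group and meta to a methoxy group.

For compound 4 in this assay a step of about an at least 1.6-fold lower number from compound 3 to compound 4 (0.22 log units; that floor lies within the scatter) is expected, resting on an at least 2.5-fold lower number from compound 1 to compound 2 (0.40 log units; beyond the scatter) and on the limit value of compound 3, > 10000 nM, which caps how much is known about the starting point. Compound 4 is therefore estimated at 6000 nM, between 2500 nM and 15000 nM, with a fair chance that only a limit is returned.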

Compound 4, half-maximal inhibitory concentration: 8030 nM
The estimate for compound 4 lay 1.3-fold (0.13 log units) below the measured number, and the stated range covers the measured number.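

In this assay, the methoxy change carried to the second core gives no sign of a different outcome, yet it does not show a matching one either: the same change on two cores in this assay, an at least 2.5-fold lower number (0.40 log units; beyond the scatter) from compound 1 to compound 2 and an at least 1.2-fold lower number (0.09 log units; that floor lies within the scatter) from compound 3 to compound 4; the limit leaves it open whether they differ

Neither step has a fixed size, and the floor of an at least 1.2-fold lower number from compound 3 to compound 4 (0.09 log units; that floor lies within the scatter) does not by itself establish a gain on the phenoxy core, because both starting compounds sit at the limit: the limit of > 10000 nM in this assay, at which 2 of the 4 values shown sit.

Among the compounds shown here, with the three methoxy groups held constant, phenoxy in place of chloro on an aromatic carbon gives a 2.0-fold higher number from compound 2 to compound 4 (0.31 log units; beyond the scatter), so the one pair with two exact numbers modestly favours the chloro compound, though a single pair does not rank the two cores in general.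

Still open, from the compounds shown here alone, is how the methoxy step would read from a starting compound with a number rather than a limit, and whether the place where the methoxy enters matters on either core. Also open, going by these compounds, is what an amine or a longer alkoxy chain in place of chloro or phenoxy would give in this assay.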